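Ether side chain of the shared core: acid to sulfonate

This account rests on a few compounds, and the source may have more. Where it says the series, first, only, none or still open, it means among the compounds named here.

Compound 1 `CCC(CC)(c1ccc(OCC(O)CO)c(C)c1)c1ccc(OCC(O)C(C)(C)C)c(OCC(O)C(C)(C)C)c1` carries a 1,2-dihydroxyethyl group on the saturated chain carbon bound to an oxygen on the aromatic ring, and in an assay on cells for binding affinity to vitamin D3 receptor (Homo sapiens), read by fluorescence, tested at 1 uM (a higher number here means more inhibition at the concentration tested (going by the name of the read-out), a lower number less inhibition), compound 1 gives 78%. Compound 2 `CCC(CC)(c1ccc(OCC(=O)O)c(C)c1)c1ccc(OCC(O)C(C)(C)C)c(OCC(O)C(C)(C)C)c1` gives 10% in this assay, so the step of a number 68 percentage points lower from compound 1 to compound 2 (beyond the scatter). Compound 3 `CCC(CC)(c1ccc(OCCCCCC(=O)O)c(C)c1)c1ccc(OCC(O)C(C)(C)C)c(OCC(O)C(C)(C)C)c1` extends the acid by a longer chain and is reported in this assay as "not active" (no number reported); no number stands for compound 3, so it cannot be placed against compound 1 or compound 2 beyond that. Compound 4 `CCC(CC)(c1ccc(OS(=O)(=O)c2ccccc2)c(C)c1)c1ccc(OCC(O)C(C)(C)C)c(OCC(O)C(C)(C)C)c1` differs from compound 3 as follows: phenylsulfonyl in place of 5-carboxypentyl on an oxygen on an aromatic ring. Among the compounds with values here, no measured step carries a phenylsulfonyl group; the only step, a number 68 percentage points lower from compound 1 to compound 2 (beyond the scatter), shows that replacing the dihydroxyethyl group by an acid costs a great deal, and both acid-bearing compounds, compound 2 and compound 3, sit low or without a number. Within the data shown here, removing the acid in compound 4 is therefore expected to give a number, but the new group has no precedent here, so a low-to-moderate reading is expected: compound 4 is estimated at 25%, with a range from 0% to 60%.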

Compound 4, a percentage reported as inhibition, at one concentration (the size of the read-out at that concentration, not a potency): "not active" (no number reported)
Nothing numeric was reported for compound 4; the estimate stays without a comparison.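

In this assay compound 3 gives "not active" (no number reported) and compound 4 gives "not active" (no number reported) so no new step can be read from this pair. No available evidence bears on this result. The compounds shown leave open how 5-carboxypentyl and phenylsulfonyl compare on this core.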